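The source may report more compounds than this note shows. Statements on the series, on what has been measured and on what is new or still open speak of the compounds shown alone.

Measured compounds and their numbers in an assay on isolated protein with fibroblast growth factor 1 (Homo sapiens) as the target; on this read-out lower numbers stand for tighter binding and higher numbers for weaker binding:
compound 1, `COC1OC(C)C(OCc2ccccc2)C(OS(=O)(=O)O)C1OS(=O)(=O)O`, gives 338000 nM;
compound 2, `O=S(=O)(O)OC[C@@H]1O[C@H](OS(=O)(=O)O)[C@H](OS(=O)(=O)O)[C@@H](OS(=O)(=O)O)[C@@H]1OS(=O)(=O)O`, gives 37500 nM;
compound 3, `O=S(=O)(O)OC[C@@H]1O[C@@H](O[C@H]2[C@H](OS(=O)(=O)O)[C@H](OS(=O)(=O)O)C(OS(=O)(=O)O)O[C@H]2COS(=O)(=O)O)[C@@H](OS(=O)(=O)O)[C@H](OS(=O)(=O)O)[C@H]1OS(=O)(=O)O`, gives 1200 nM.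

Among these three, compound 3 stands at the lowest number; compound 2 sits higher and compound 1 higher still, and both of those gaps lie well beyond the scatter. Compound 4, `O=S(=O)(O)OC[C@@H]1O[C@H](O[C@H]2[C@H](OS(=O)(=O)O)[C@H](OS(=O)(=O)O)C(OS(=O)(=O)O)O[C@H]2COS(=O)(=O)O)[C@@H](OS(=O)(=O)O)[C@H](OS(=O)(=O)O)[C@H]1OS(=O)(=O)O`, keeps every atom and bond of compound 3 and differs only in stereochemistry: the two compounds have the same atoms and bonds; at least one stereo element is drawn with a configuration in one of them and without one in the other: 1 of 10 stereo elements differ; a stereocentre at a saturated ring carbon is drawn S in compound 3 and R in compound 4. Going by the values given here, no pair of measured compounds shows what such a change does here, so the step of a 1.7-fold higher number from compound 3 to compound 4 (0.22 log units; within the scatter) is expected to be small and without a clear direction beyond the scatter. Compound 4 is therefore estimated at 2000 nM, within a range of 500 nM to 8000 nM.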

Compound 4, dissociation constant: 540 nM
The estimate for compound 4 lay 3.7-fold (0.57 log units) above the measured number; the range from low to high includes it.
By their numbers in this assay, from the lowest: compound 4; then compound 3; then compound 2; then compound 1.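

Changing one stereocentre at a saturated ring carbon from S to R, with atoms and bonds untouched, gives a 2.2-fold lower number from compound 3 to compound 4 (0.35 log units; beyond the scatter) in this assay. Going by these compounds alone, the earlier compounds held no such pair, so this is the first sign that configuration alone can move the number here, though only modestly. One caution attaches to this reading: the fact that one of compounds 3 and 4 is drawn with a defined configuration and the other without, at the place where they differ.

The compounds shown leave open whether the same change would matter on another core. They also leave open what an amine or a carboxylic acid in place of a sulfate group would do.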